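A few compounds are considered here, and "the series" means these few. Any claim that something is new, unique, unknown or untested is made for them only; others in the source may bear on it.

Working notes on the series. Compound 1 `Cn1c(CN2CCC(c3ccc(Cl)cc3)CC2)nc2ccccc21` and compound 2 `Cn1c(CN2CCN(c3nc4ccccc4s3)CC2)nc2ccccc21` share the core; they differ in the whole group hung on the saturated ring. In a functional assay on CHO cells for agonist activity at metabotropic glutamate receptor 2 (Homo sapiens), read by FLIPR (on this read-out higher numbers stand for an effect only at larger amounts of compound and lower numbers for an effect already at smaller amounts), compound 1 gives 5010 nM, and in this assay compound 2 gives 2000 nM. Compound 1 thus carries the highest number of the two, and the gap to compound 2 lies beyond the usual scatter. Within the data shown here, no compound pair with a single-point change has been measured, so no comparable step is available as a guide.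

Compound 3 `Cn1c(CN2CCC(c3ccccc3F)CC2)nc2ccccc21` is not yet measured. It differs from compound 1 in one place: 2-fluorophenyl in place of 4-chlorophenyl on a saturated ring carbon. The halogen changes and its position on the phenyl ring changes at the same time, and there is nothing in the measured pair that speaks to either. The expectation is therefore a step of modest size in this assay, in either direction, with no firm lean; the estimated step from compound 1 to compound 3 is a 1.2-fold higher number from compound 1 to compound 3 (0.08 log units; within the scatter). Compound 3 is accordingly expected to give about 6000 nM, within a range from 2000 nM to 18000 nM.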

Compound 3, half-maximal effective concentration: 3980 nM
Estimate against measurement, compound 3: 1.5-fold (0.18 log units) above; low and high end bracket the measured number.
By their numbers in this assay, from the lowest: compounds 2, 3 and 1 (each within the scatter of the next, the first and the last beyond it).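

Among these compounds, the step from 4-chlorophenyl to 2-fluorophenyl on a saturated ring carbon, three ring bonds from the ring nitrogen, is the first single-place step: in this assay it gives a 1.3-fold lower number from compound 1 to compound 3 (0.10 log units; within the scatter). This position therefore accepts a change of halogen and a change of its place on the phenyl ring, made together, without a step beyond the scatter, and both groups count the same under heavy atoms, donors and acceptors. Nothing available bears on why the step is this size, and a combined change cannot show what either part would do alone.

Still open, going by these compounds, is what each part contributes, which 4-fluorophenyl or 2-chlorophenyl in the same place could separate, since only those two would change the halogen or its place alone. Also open, on these data alone, is whether this position stays as undemanding with a group of another kind, such as a phenyl ring carrying a carboxylic acid or an amine, which would bring hydrogen-bond donors or acceptors to a place where so far there are none.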